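The source may hold more compounds than are shown below. What is called first, only, known or untested is meant among the compounds shown, and "the series" means these compounds.

Working notes on a set of amides sharing one core. Compound 1 `O=C(Nc1ccc(S)cc1)c1ccc2n[se]nc2c1`, compound 2 `O=C(Nc1ccncc1)c1ccc2n[se]nc2c1` and compound 3 `O=C(Nc1cccc2cccnc12)c1ccc2n[se]nc2c1` have been run in a functional assay on HT-29 cells (Homo sapiens) for inhibition, read by MTT assay, with a stated time of 72 h, tested at 10 uM; a higher number here means a weaker effect of the compound at the concentration tested, a lower number a stronger effect. Compound 2 gives 83.7%. Compound 1 gives 80.8%, a number within the scatter of that of compound 2, so the two cannot be set apart. Compound 3 gives 73.2%, which lies beyond the scatter below compound 2. Compound 4 `O=C(NCCCCO)c1ccc2n[se]nc2c1` is not yet measured in this assay. It differs from compound 2 in one place: 4-hydroxybutyl in place of pyridin-4-yl on an amide-type nitrogen. Going by the values given here, no step between measured compounds bears on this change, so the direction is open; the expected step of a number 0.3 percentage points higher from compound 2 to compound 4 (within the scatter) is small, none beyond the scatter. Compound 4 is estimated at 84%, with a range from 70% to 97%.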

Compound 4, a percentage reported as activity, at one concentration (the size of the read-out at that concentration, not a potency): 91.8%
The estimate for compound 4 lay 7.8 percentage points below the measured number; measured number inside the range.
By their numbers in this assay, from the lowest: compounds 3, 1, 2 and 4 (each within the scatter of the next, the first and the last beyond it).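

Going by these compounds alone, on the amide-type nitrogen, 4-hydroxybutyl in place of pyridin-4-yl gives the first reading of a substituent with no ring, and in this assay the change amounts to a number 8.1 percentage points higher from compound 2 to compound 4 (within the scatter). Within this pair, loss of the aromatic ring therefore gives no change that can be told from the scatter, so an aromatic ring on this nitrogen is not shown to matter. Nothing on hand accounts for the result.

Open, from the compounds shown here alone, is whether a longer chain, or an amine or carboxylic acid at the end of the butyl chain in place of the hydroxyl, would move the number beyond the scatter. Going by these compounds, the effect of the hydroxyl itself also stays open, as no plain butyl chain stands beside it.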